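The compounds below may be only part of what the source reports. "The series", "measured", "known", "first", "only" and "open" are said of these compounds alone.

Measured in an ADME assay on microsomes from liver (Homo sapiens) for metabolic stability; on this read-out higher numbers stand for fast clearance and lower numbers for slow clearance:
- compound 1 `Cc1cccc([C@H](C)NC(=O)Cn2nnc3ccccc3c2=O)c1` gives 11 mL/min/kg
- compound 2 `C[C@@H](NC(=O)Cn1nnc2ccccc2c1=O)c1ccccc1` gives < 9.9 mL/min/kg, a limit of the assay and not a number
- compound 3 `C[C@H](NC(=O)Cn1nnc2ccccc2c1=O)c1ccc(F)cc1` gives 31 mL/min/kg

Of the two actual numbers in this assay, the higher belongs to compound 3 at 31 mL/min/kg. The other belongs to compound 1 at 11 mL/min/kg. The remaining value, that of compound 2, is a limit.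

Next in the series is compound 4 `Cc1ccc([C@H](C)NC(=O)Cn2nnc3ccccc3c2=O)c(C)c1`, with 2,4-dimethylphenyl in place of 4-fluorophenyl on a saturated chain carbon bound to an amide-type nitrogen and a saturated chain carbon.

For the measured compounds named here, only one measured step bears on this change: a 2.8-fold higher number from compound 1 to compound 3 (0.45 log units; beyond the scatter). That step put 4-fluorophenyl in place of 3-methylphenyl, and the present change removes 4-fluorophenyl again in favour of a methyl-bearing phenyl. Read in reverse, it points toward a lower number, of similar or smaller size. Going by the values given here, no measured compound carries 2,4-dimethylphenyl, and a single step is thin support, so the expectation remains loose.

The expected change in this assay is a 2.1-fold lower number from compound 3 to compound 4 (0.32 log units; beyond the scatter), a modest estimated move toward slower clearance. For compound 4 the estimated value is 15 mL/min/kg, with an expected range of 8 mL/min/kg to 32 mL/min/kg.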

Compound 4, clearance: 33 mL/min/kg
The estimate for compound 4 lay 2.2-fold (0.34 log units) below the measured number; measured number above the stated range.
By their numbers in this assay, from the lowest: compound 1; then compounds 3 and 4 (each within the scatter of the next). At a limit, below all of these: compound 2.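

In this assay the 2,4-dimethylphenyl of compound 4 and the 4-fluorophenyl of compound 3 cannot be told apart on the saturated chain carbon bound to an amide-type nitrogen and a saturated chain carbon, with a 1.1-fold higher number from compound 3 to compound 4 (0.03 log units; within the scatter) as the step. Carrying methyl on the phenyl is therefore not enough to hold the number at the level of compound 1, as a 3.0-fold higher number from compound 1 to compound 4 (0.48 log units; beyond the scatter) separates the 3-methylphenyl from the 2,4-dimethylphenyl. Fluorine is also not required for the higher level, since compound 4 has none and still shares that level with compound 3, leaving compound 1 as the only compound with a number that stands apart from the other two.

As far as these compounds go, compound 2, with an unsubstituted phenyl, carries a limit and not a number, so its distance from the others stays open: the limit of < 9.9 mL/min/kg in this assay, at which 1 of the 4 values shown sits. Also open, from the compounds shown here alone, is how a methoxy group, a nitrile or an amine on the phenyl, or an ethyl group in place of the methyl on the chain carbon, would read in this assay.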